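Swapping the Vinyl Group for Methylsulfinyl on a Deoxyuridine

This account rests on a few compounds, and the source may have more. Where it says the series, first, only, none or still open, it means among the compounds named here.

Compound 1 `CC1(C)[C@@H](Cn2ccc(=O)[nH]c2=O)CC[C@@]1(C)CO`: in an ADME assay on L1210/0 cells (Mus musculus) for cytotoxicity, with a stated time of 48 h (on this read-out higher numbers stand for weaker inhibition and lower numbers for stronger inhibition), compound 1 gives > 200000 nM, which is a limit of the assay and not a number.
Compound 2 `Nc1ncnc2c1nnn2C1C[C@H](CO)[C@@H](CO)[C@@H]1CO`: in this assay compound 2 gives > 200000 nM, again a limit of the assay.
Compound 3 `C=Cc1cn([C@H]2C[C@H](O)[C@@H](CO)O2)c(=O)[nH]c1=O`: in this assay compound 3 gives 14200 nM.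

Within the data shown here, compound 3 thus holds the only measured number here, while the other two compounds rest at the limit of > 200000 nM in this assay, at which 2 of the 3 values shown sit. Compound 4 `C[S+]([O-])c1cn([C@H]2C[C@H](O)[C@@H](CO)O2)c(=O)[nH]c1=O` has not yet been measured. It differs from compound 3 by a group of 3 heavy atoms (1 carbon, 1 oxygen, 1 sulfur; no ring) in place of a group of 2 heavy atoms (2 carbon; no ring), on an aromatic carbon. Among the measured compounds shown here, no pair of measured compounds differs in a single place, so the data give no direct guide to the size of this step. Compound 4 is expected to inhibit less strongly than compound 3, with an expected step of a 6.3-fold higher number from compound 3 to compound 4 (0.80 log units; beyond the scatter), and a real chance that only a limit is reported. The estimate for compound 4 in this assay is 90000 nM, within 20000 nM to 400000 nM.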

Compound 4, half-maximal inhibitory concentration: > 200000 nM
Compound 4: only a limit was reported (the forecaster's own chance of this, stated with the estimate: 40%); middle value at least 2.2-fold (0.34 log units) from the limit.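

On this aromatic carbon the choice of group clearly matters in this assay: replacing vinyl with methylsulfinyl gives an at least 14-fold higher number from compound 3 to compound 4 (1.14 log units; beyond the scatter). Among these compounds, this is the first step that can be read, and it shows that activity can be lost through a change at this one place. Compound 4 gives a limit of the assay and not a number, and it joins the compounds already there: the limit of > 200000 nM in this assay, at which 3 of the 4 values shown sit.

Going by these compounds, only compound 3 keeps a measured number, so the true size of the step remains open. On these data alone, whether an ethyl group, a longer chain or an amine here would behave like vinyl or like methylsulfinyl also remains open.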